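Changing the Aryl Group: What Cytotoxicity to Expect

This account rests on a few compounds, and the source may have more. Where it says the series, first, only, none or still open, it means among the compounds named here.

Three analogues built on one shared core have been tested in an ADME assay on MT4 cells (Homo sapiens) for cytotoxicity, read by MTT assay, with a stated time of 4 days; on this read-out higher numbers stand for lower toxicity in this test and lower numbers for higher toxicity in this test. Compound 1 `Cc1cc(-c2ccc(C#N)cc2)cc(C)c1Nc1ccnc(Nc2ccc(C#N)cc2)n1` gives 2080 nM. Compound 2 `Cc1cc(-c2cccc(F)c2)cc(C)c1Nc1ccnc(Nc2ccc(C#N)cc2)n1` gives 4120 nM. Compound 3 `Cc1cc(-c2ccc(C(F)(F)F)cc2)cc(C)c1Nc1ccnc(Nc2ccc(C#N)cc2)n1` gives 4160 nM. Three steps connect these numbers: a 2.0-fold higher number from compound 1 to compound 2 (0.30 log units; within the scatter), a 2.0-fold higher number from compound 1 to compound 3 (0.30 log units; within the scatter), and a 1.0-fold higher number from compound 2 to compound 3 (0.00 log units; within the scatter). Every one of them lies within the scatter of this assay, so compound 3 sits among numbers that cannot be told apart from its own; its position at the upper edge of the three carries no weight.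

Compound 4 `Cc1cc(C)cc(-c2cc(C)c(Nc3ccnc(Nc4ccc(C#N)cc4)n3)c(C)c2)c1` is the next variation on the same core, and differs from compound 3 in one place: 3,5-dimethylphenyl in place of 4-(trifluoromethyl)phenyl on an aromatic carbon. All three measured steps bear on this change, since each of them also swaps the aryl group attached at this position, and none of them moved the number beyond the scatter. With every exchange of the aryl group so far giving no detectable effect, the step from compound 3 to compound 4 in this assay is expected to be a 1.1-fold lower number from compound 3 to compound 4 (0.04 log units; within the scatter), again within the scatter. Compound 4 is therefore estimated at 3800 nM in this assay, with a plausible range from 1500 nM to 10000 nM.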

Compound 4, half-maximal cytotoxic concentration: 4140 nM
For compound 4 the middle estimate is 1.1-fold (0.04 log units) below the measured one, within the range that was stated.
By their numbers in this assay, from the lowest: compounds 1, 2, 4 and 3 (each within the scatter of the next).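

In this assay, placing 3,5-dimethylphenyl on this aromatic carbon gives a 1.0-fold lower number from compound 3 to compound 4 (0.00 log units; within the scatter), while the comparisons with the other two aryl groups give a 1.0-fold higher number from compound 2 to compound 4 (0.00 log units; within the scatter) and a 2.0-fold higher number from compound 1 to compound 4 (0.30 log units; within the scatter), so none of the three new steps can be told apart from repeat-measurement noise. What compound 4 adds is a group built of carbon only: the aryl groups of compound 1, compound 2 and compound 3 each carry a cyano, fluoro or trifluoromethyl group, yet removing these atoms from the ring leaves no detectable change in this read-out, and two methyl groups on the ring fit the same picture. No supporting data are available to say why these four aryl groups read alike.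

All four compounds carry a substituted phenyl ring at this place, so the compounds shown leave open whether an amine or a carboxylic acid on that ring, a longer chain, or no aryl group at all would move the number beyond the scatter. They also leave open whether this flat picture holds in any read-out other than this cytotoxicity test.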